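A few compounds are considered here, and "the series" means these few. Any claim that something is new, unique, unknown or untested is made for them only; others in the source may bear on it.

Of the compounds shown here, three have been measured for their effect on breast-cancer cell growth in a functional assay on MCF7 cells (Homo sapiens) for cytotoxicity, read by sulforhodamine B assay, with a stated time of 48 h; a lower number here means a stronger inhibitor of growth, a higher number a weaker inhibitor of growth. Compound 1 `CCN(CC)CN1C(=O)/C(=N\c2nc3ccc(C)cc3s2)c2ccccc21` gives 74800 nM in this assay. Compound 2 `CCN(CC)CN1C(=O)/C(=N\c2nc3ccc(C)cc3s2)c2c(Br)cccc21` gives 30200 nM. Compound 3 `CN(C)CN1C(=O)C(=O)c2c(Br)cccc21` differs from compound 2 in a way that is not broken down here; in this assay compound 3 gives 57600 nM, a number that lies within the usual scatter of both compound 1 and compound 2, so no order among these three can be stated. Among the compounds with values here, the only counted step among the measured compounds runs from compound 2 to compound 1: it is hydrogen in place of bromo on an aromatic carbon, and it produced a 2.5-fold higher number from compound 2 to compound 1 (0.39 log units; beyond the scatter), a modest weakening of growth inhibition.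

Compound 4 `CN(C)CN1C(=O)C(=O)c2ccccc21` has not yet been measured in this assay. It differs from compound 3 by hydrogen in place of bromo on an aromatic carbon. The place of this change is described in the same words as for the change from compound 2 to compound 1, so it is the same change carried out on the core of compound 3 rather than the core of compound 2. The step from compound 3 to compound 4 is therefore expected to be a 2.3-fold higher number from compound 3 to compound 4 (0.35 log units; beyond the scatter). That expectation rests on compound 2 and compound 1, where the same change gave a 2.5-fold higher number from compound 2 to compound 1 (0.39 log units; beyond the scatter), and on the starting value of compound 3, which is already weak. Compound 4 is accordingly estimated to give about 130000 nM in this assay. The expected range for compound 4 runs from 60000 nM to 300000 nM. A number this high may be reported only as a limit of the assay rather than as a measured value.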

Compound 4, concentration for 50% growth inhibition: 40500 nM
Compound 4: the middle estimate sits 3.2-fold (0.51 log units) above what was measured; measured number below the stated range.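

In this assay, hydrogen in place of bromo on the aromatic carbon gave a 1.4-fold lower number from compound 3 to compound 4 (0.15 log units; within the scatter) and so left no difference that can be told from the scatter on this core, whereas the same change on the core of compound 2 gave a 2.5-fold higher number from compound 2 to compound 1 (0.39 log units; beyond the scatter) as a modest step. The size of this change therefore did not carry over from one core to the other in this series: the same change on two cores in this assay, a 2.5-fold higher number (0.39 log units; beyond the scatter) from compound 2 to compound 1 and a 1.4-fold lower number (0.15 log units; within the scatter) from compound 3 to compound 4, 3.5-fold (0.55 log units) apart, beyond the scatter of two such steps. This rests on a single pair of compounds for each core, and the two pairs differ from each other in more than one place, so it shows that the step cannot simply be transferred between these two cores, but it does not show which difference between them matters, and it gives no rule for any further core.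

The compounds shown leave open how a chloro, fluoro or methoxy group on that same aromatic carbon would compare with bromo and hydrogen on either core. They also leave open whether a morpholine or piperidine in place of the dimethylamino group of compound 3 would bring the step closer to the one seen on the core of compound 2.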